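Same atoms rejoined: from compound 2 to compound 4

This account rests on a few compounds, and the source may have more. Where it says the series, first, only, none or still open, it means among the compounds named here.

Of the compounds shown here, three carry numbers so far. In an ADME assay on microsomes from liver (Homo sapiens) for metabolic stability, read by LC-MS, with a stated time of 30 min, tested at 1 uM (a higher number here means that more of the compound is left, a lower number that less of the compound is left), compound 1 `O=C(NCc1ccc(S(=O)(=O)c2ccccc2)cc1)c1ccc2nccn2c1` gives 77% and compound 3 `Cn1c(C(=O)NCc2ccc(S(=O)(=O)c3ccccc3)cc2)cc2ccncc21` gives 71% in the same read-out. Compound 2 `O=C(NCc1ccc(S(=O)(=O)N2CCCCC2)cc1)c1cc2cnccc2o1` stands lowest of the three at 46% and lies beyond the scatter from both compound 1 and compound 3.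

Compound 4 `O=C(NCc1ccc(S(=O)(=O)N2CCCCC2)cc1)c1cc2ccncc2o1` has not yet been measured. Its difference from compound 2 reads a group of 9 heavy atoms (7 carbon, 1 nitrogen, 1 oxygen; one five-membered aromatic ring with 1 hetero atom, one six-membered aromatic ring with 1 hetero atom) in place of a group of 9 heavy atoms (7 carbon, 1 nitrogen, 1 oxygen; one five-membered aromatic ring with 1 hetero atom, one six-membered aromatic ring with 1 hetero atom), on a carbonyl carbon and the two have the same atoms, joined differently. The rest of the molecule is unchanged.

Going by the values given here, no two measured compounds differ in one place only, and this change therefore has no measured step to guide its size. The closest reference is compound 2 at 46% in this assay and the higher values of the other two compounds give no separate measure of this change. The expected step of a number 4 percentage points higher from compound 2 to compound 4 (within the scatter) is small, slightly upward and not beyond the scatter. Compound 4 is expected at 50% with an estimated range from 32% to 68% for repeated measurements.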

Compound 4, percent of the compound remaining: 56%
Compound 4: middle estimate off by 6 percentage points, on the low side; the measured number falls inside the stated range.
By their numbers in this assay, from the lowest: compounds 2 and 4 (each within the scatter of the next); then compounds 3 and 1 (each within the scatter of the next).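

Rejoining the same atoms in the group on the carbonyl carbon whose other neighbour is the amide-type nitrogen gives the series its first step that differs in one place only: in this assay, the reading is a number 10 percentage points higher from compound 2 to compound 4 (within the scatter). For this pair, then, changing how the atoms of the two-ring group are joined does not separate the compounds beyond the scatter, and the reading gives no sign that this connectivity matters at this place while the rest of the molecule stays fixed. No measured information on the compounds bears on this reading.

Steps from compound 2 or compound 4 to compound 1 or compound 3 cannot be read, as those pairs differ in more than one place, so the numbers of compound 1 and compound 3 cannot be tied to any single part of the structure. Still open, on these data alone, is whether a group of another kind on the same carbonyl carbon, such as a morpholine or a carboxylic acid-bearing phenyl ring, would give a step beyond the scatter in this assay.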